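Compound 2 at the limit: replacing 2-methoxyphenyl

This account rests on a few compounds, and the source may have more. Where it says the series, first, only, none or still open, it means among the compounds named here.

In a functional assay on MCF7 cells (Homo sapiens) for inhibition, read by MTT assay (on this read-out higher numbers stand for weaker inhibition and lower numbers for stronger inhibition), compound 1 `COc1cc2ncnc(Nc3ccc(NC(=O)c4cccc(C)c4)cc3)c2cc1OC` gives 13000 nM and compound 3 `COc1cc2ncnc(Nc3ccc(NC(=O)c4ccc(F)cc4)cc3)c2cc1OC` gives 27000 nM. Compound 2 `COc1cc2ncnc(Nc3ccc(NC(=O)c4ccccc4OC)cc3)c2cc1OC` is recorded only as a limit, > 100000 nM. Compound 4 `COc1cc2ncnc(Nc3ccc(NC(=O)c4ccc(Cl)cc4)cc3)c2cc1OC` has 4-chlorophenyl in place of 2-methoxyphenyl on a carbonyl carbon. The closest measured precedent is an at least 3.7-fold lower number from compound 2 to compound 3 (0.56 log units; beyond the scatter), where compound 3 replaces the same 2-methoxyphenyl with 4-fluorophenyl. Also relevant are an at least 7.6-fold higher number from compound 1 to compound 2 (0.88 log units; beyond the scatter) and the smaller 2.1-fold higher number from compound 1 to compound 3 (0.32 log units; beyond the scatter), which place compound 2 well above both measured neighbours. A step of similar size towards a lower number is therefore expected in this assay. The expected change is an at least 4.0-fold lower number from compound 2 to compound 4 (0.60 log units; beyond the scatter). For compound 4 the estimated value is 25000 nM, with an expected range of 10000 nM to 70000 nM.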

Compound 4, half-maximal inhibitory concentration: 30000 nM
Estimate against measurement, compound 4: 1.2-fold (0.08 log units) below; low and high end bracket the measured number.
By their numbers in this assay, from the lowest: compound 1; then compounds 3 and 4 (each within the scatter of the next). At a limit, above all of these: compound 2.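

In this assay, 4-chlorophenyl and 4-fluorophenyl on the carbonyl carbon cannot be told apart, with a 1.1-fold higher number from compound 3 to compound 4 (0.05 log units; within the scatter), while 3-methylphenyl keeps the lower number, with a 2.3-fold higher number from compound 1 to compound 4 (0.36 log units; beyond the scatter). The 2-methoxyphenyl group stays apart from the second halogen as well, with an at least 3.3-fold lower number from compound 2 to compound 4 (0.52 log units; beyond the scatter). Compound 2 is a limit, so that step has no fixed size: the limit of > 100000 nM in this assay, at which 1 of the 4 values shown sits.

The compounds shown leave open whether a 3-chlorophenyl would read with compound 1 or with compound 4. On these data alone, how a 4-methoxyphenyl would read, set against the 2-methoxyphenyl of compound 2, is also open.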